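A few compounds are considered here, and "the series" means these few. Any claim that something is new, unique, unknown or untested is made for them only; others in the source may bear on it.

In a functional assay on P388 cells (Mus musculus) for cytotoxicity (on this read-out lower numbers stand for stronger inhibition and higher numbers for weaker inhibition), compound 1 (`C=CC[C@@H]1NC(=O)[C@@H](C)NC(=O)[C@@H]2Cc3ccc(OC)c(c3)Oc3ccc(cc3)C[C@@H](C(=O)N2C)N(C)C(=O)[C@H](C)NC(=O)[C@H](Cc2ccc(OC)cc2)N(C)C1=O`) gives 38.9 nM, compound 2 (`COc1ccc(C[C@H]2C(=O)N[C@@H](C)C(=O)N(C)[C@H]3Cc4ccc(cc4)Oc4cc(ccc4OC)C[C@@H](C(=O)N[C@H](C)C(=O)N[C@@H](CCCN=[N+]=[N-])C(=O)N2C)N(C)C3=O)cc1`) gives 35.5 nM and compound 3 (`COc1ccc(C[C@H]2C(=O)N[C@@H](C)C(=O)N(C)[C@H]3Cc4ccc(cc4)Oc4cc(ccc4OC)C[C@@H](C(=O)N[C@H](C)C(=O)N[C@@H](CCO)C(=O)N2C)N(C)C3=O)cc1`) gives 60.3 nM. Compound 3 therefore stands within the scatter of both other compounds, and the three numbers form one group. Compound 4 (`C=C[C@@H]1NC(=O)[C@@H](C)NC(=O)[C@@H]2Cc3ccc(OC)c(c3)Oc3ccc(cc3)C[C@@H](C(=O)N2C)N(C)C(=O)[C@H](C)NC(=O)[C@H](Cc2ccc(OC)cc2)N(C)C1=O`) has vinyl in place of 2-hydroxyethyl on a saturated ring carbon. The measured steps that bear on this change are a 1.6-fold higher number from compound 1 to compound 3 (0.19 log units; within the scatter), a 1.7-fold higher number from compound 2 to compound 3 (0.23 log units; within the scatter) and a 1.1-fold lower number from compound 1 to compound 2 (0.04 log units; within the scatter). All three lie within the scatter, even though the group on the chain differs each time. For the measured compounds named here, none of them shows vinyl on a saturated ring carbon, however, because in compound 1, the only measured compound with vinyl, that group stands on a saturated chain carbon, so the evidence is indirect. No step beyond the scatter is therefore expected in this assay. The estimate is a 1.3-fold lower number from compound 3 to compound 4 (0.13 log units; within the scatter). The expected value for compound 4 is 45 nM, with an estimated range of 18 nM to 110 nM.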

Compound 4, half-maximal inhibitory concentration: 25.7 nM
Beside the measured number, compound 4's estimate is 1.8-fold (0.24 log units) above it, within the range that was stated.
By their numbers in this assay, from the lowest: compounds 4, 2, 1 and 3 (each within the scatter of the next, the first and the last beyond it).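

In this assay, vinyl in place of 2-hydroxyethyl on this saturated ring carbon gives a 2.3-fold lower number from compound 3 to compound 4 (0.37 log units; beyond the scatter), a modest step and the only one among these compounds that passes the scatter. Set against the other two chains, vinyl gives a 1.4-fold lower number from compound 2 to compound 4 (0.14 log units; within the scatter) for 3-azidopropyl and a 1.5-fold lower number from compound 1 to compound 4 (0.18 log units; within the scatter) for allyl, so the position separates only the vinyl and 2-hydroxyethyl pair, while 3-azidopropyl and allyl stay within the scatter of vinyl. No measured evidence accounts for this step.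

The compounds shown leave open whether the hydroxy group or the chain itself carries the gap, as 2-hydroxyethyl and vinyl differ in both. On these data alone, how a plain ethyl chain, or an amine or a carboxylic acid at the chain end, would read in this assay also stays open.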